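A few compounds are considered here, and "the series" means these few. Any claim that something is new, unique, unknown or untested is made for them only; others in the source may bear on it.

Measured in a functional assay on HCT-116 cells (Homo sapiens) for cytotoxicity, read by scintillation counting and thymidine incorporation, with a stated time of 72 h; on this read-out higher numbers stand for weaker inhibition and lower numbers for stronger inhibition:
- Compound 1 `C=C(c1cc(OC)cc(OC)c1)c1ccc(OC)c(OC)c1`: > 10000 nM (a limit)
- Compound 2 `COc1cc(OC)cc(C(=CCCN(C)C)c2ccc(OC)c(OC)c2)c1`: > 10000 nM (a limit)
- Compound 3 `CC=C(c1cc(OC)cc(OC)c1)c1ccc(OC)c(OC)c1`: 480 nM

For the measured compounds named here, compound 3 holds the only true number in this small set. The other two compounds stand at the limit of > 10000 nM in this assay, at which 2 of the 3 values shown sit.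

Compound 4 `COC(=O)C=C(c1cc(OC)cc(OC)c1)c1ccc(OC)c(OC)c1` keeps the shared core and changes one group: methoxycarbonyl in place of methyl on a double-bonded chain carbon bound to a double-bonded chain carbon. Here methoxycarbonyl takes the place of methyl on a double-bonded chain carbon bound to a double-bonded chain carbon.

The measured steps along this same chain are the best guide. The two readable ones are large: an at least 20-fold lower number from compound 1 to compound 3 (1.31 log units; beyond the scatter), and an at least 20-fold lower number from compound 2 to compound 3 (1.31 log units; beyond the scatter). The third is a step that the two limits leave unreadable from compound 1 to compound 2.

So far, the methyl group of compound 3 is the only group on this chain to give a number, at 480 nM. Removing that methyl is therefore expected to give back part of the gain seen in an at least 20-fold lower number from compound 1 to compound 3 (1.31 log units; beyond the scatter), and a higher number is likely. The expected change is a 6.3-fold higher number from compound 3 to compound 4 (0.80 log units; beyond the scatter). For compound 4 the estimated value is 3000 nM, with an expected range from 600 nM to 10000 nM.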

Compound 4, half-maximal inhibitory concentration: > 10000 nM
Compound 4 was reported as a limit (the forecaster's own chance of this, stated with the estimate: 35%); middle value at least 3.3-fold (0.52 log units) away from the limit.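

In this assay, replacing methyl with methoxycarbonyl gives an at least 20-fold higher number from compound 3 to compound 4 (1.31 log units; beyond the scatter), so a larger group with hydrogen-bond acceptors does not keep the activity seen with methyl at this place. Until now, methyl had been compared only with hydrogen and 2-(dimethylamino)ethyl; methoxycarbonyl is a third group that yields no number, and the result for compound 4 is itself a limit. Methyl therefore remains the only group on this double-bonded chain carbon with a true value, and the limit now covers most of the set: the limit of > 10000 nM in this assay, at which 3 of the 4 values shown sit.

The steps among compound 1, compound 2 and compound 4 cannot be read, since each joins two limits, so these three compounds cannot be ranked. On these data alone, it remains open whether an ethyl group, a hydroxymethyl group or a carboxylic acid at this place would give a number, and so how narrowly activity here depends on methyl.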